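The source may report more compounds than this note shows. Statements on the series, on what has been measured and on what is new or still open speak of the compounds shown alone.

The compounds share one core, on which a carbonyl group is carried through an aromatic ring. Compound 1 `COc1cc(-c2nn(-c3cccc(NC(=O)Nc4ccc(Cl)c(Cl)c4)c3)cc2-c2ccncc2)ccc1Cl` has a methyl on an oxygen on an aromatic ring and a (3,4-dichlorophenyl)amino on the carbonyl carbon. In a functional assay on UACC-257 cells (Homo sapiens) for inhibition, read by sulforhodamine B assay, with a stated time of 48 h (on this read-out lower numbers stand for higher toxicity in this test and higher numbers for lower toxicity in this test), compound 1 gives only a limit of the test, > 50000 nM, so its position on the scale is not known beyond that (the limit of > 50000 nM in this assay, at which 1 of the 3 values shown sits). Compound 2 `O=C(Nc1cccc(-n2cc(-c3ccncc3)c(-c3ccc(Cl)c(O)c3)n2)c1)Nc1ccc(Cl)c(Cl)c1` has hydrogen in place of methyl on an oxygen on an aromatic ring. In this assay compound 2 also reaches only a limit, > 32500 nM (the limit of > 32500 nM in this assay, at which 1 of the 3 values shown sits). The step that the two limits leave unreadable from compound 1 to compound 2 therefore cannot be read. Within the data shown here, compound 3 `O=C(Nc1cccc(-n2cc(-c3ccncc3)c(-c3ccc(Cl)c(O)c3)n2)c1)Nc1cc(C(F)(F)F)cc(C(F)(F)F)c1` carries a different group on the carbonyl carbon; in this assay compound 3 gives 10600 nM, the only number in the set.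

Compound 4 `COc1cc(-c2nn(-c3cccc(NC(=O)c4ccccc4)c3)cc2-c2ccncc2)ccc1Cl` differs from compound 1 by phenyl in place of (3,4-dichlorophenyl)amino on a carbonyl carbon, so the ((3,4-dichlorophenyl)carbamoyl)amino group becomes benzamido. Among the measured compounds shown here, no measured step covers this change, and the one measured step is unreadable. Compound 4 is therefore expected to remain near the limit of compound 1, with the step of a number no higher from compound 1 to compound 4 (the limit leaves the size open) estimated as none beyond the scatter. The estimated value for compound 4 in this assay is 50000 nM, expected between 15000 nM and 100000 nM.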

Compound 4, concentration lethal to 50% of the cells: > 100000 nM
Compound 4: a limit, no number; the forecaster's own chance of this, stated with the estimate: 70%; middle value at least 2.0-fold (0.30 log units) away from the limit.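

In this assay compound 4 gives > 100000 nM as a limit of the test, not a number. Compound 1 also stands only at a limit, so the step between compound 1 and compound 4 cannot be read. Going by these compounds, how far phenyl in place of (3,4-dichlorophenyl)amino on a carbonyl carbon shifts toxicity in this test stays open.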